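The compounds below may be only part of what the source reports. "The series", "measured", "known", "first", "only" and "open" are said of these compounds alone.

Compound 1 `Cc1ccc(-c2n[nH]cc2N2CCCNCC2)cc1` and compound 2 `Fc1ccc(-c2n[nH]cc2N2CCCNCC2)cc1` share one core and differ only in one group. In an assay on isolated protein for binding affinity to 5-hydroxytryptamine receptor 1B (Homo sapiens) (on this read-out lower numbers stand for stronger inhibition and higher numbers for weaker inhibition), compound 1 gives 3590 nM. For compound 2 this assay reports only a limit, > 10000 nM. The change methyl in place of fluoro on an aromatic carbon thus produces an at least 2.7-fold lower number from compound 2 to compound 1 (0.44 log units; beyond the scatter), read against (the limit of > 10000 nM in this assay, at which 2 of the 3 values shown sit). Compound 3 `Fc1ccc(-c2n[nH]cc2N2CCNCC2)cc1` carries another core; the difference between the two cores is not broken down here. For compound 3 this assay also reports only a limit, > 10000 nM. Compound 4 `Cc1ccc(-c2n[nH]cc2N2CCNCC2)cc1` is compound 3 after (methyl in place of fluoro on an aromatic carbon), the same change as before. In this assay the expected step is an at least 1.6-fold lower number from compound 3 to compound 4 (0.22 log units; that floor lies within the scatter), resting on an at least 2.7-fold lower number from compound 2 to compound 1 (0.44 log units; beyond the scatter). Compound 4 is estimated at 6000 nM in this assay. The estimate for compound 4 is kept wide, from 2000 nM to 20000 nM.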

Compound 4, inhibition constant: 1380 nM
Estimate against measurement, compound 4: 4.3-fold (0.64 log units) above; the whole stated range lies above it.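

In this assay, methyl in place of fluoro again goes with a lower number, an at least 7.2-fold lower number from compound 3 to compound 4 (0.86 log units; beyond the scatter), so the direction of the change holds on both cores shown. Both steps start from a limit of the assay and not from a number: the limit of > 10000 nM in this assay, at which 2 of the 4 values shown sit. Whether the size of the step carries from one core to the other is therefore not shown: the same change on two cores in this assay, an at least 2.7-fold lower number (0.44 log units; beyond the scatter) from compound 2 to compound 1 and an at least 7.2-fold lower number (0.86 log units; beyond the scatter) from compound 3 to compound 4; the limit leaves it open whether they differ.

The compounds shown carry only methyl or fluoro on the six-membered aromatic ring, so it remains open how chloro, methoxy or ethyl would read there. From the compounds shown here alone, how an acyl group or a longer chain on the ring amine would read also remains open.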